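This account rests on a few compounds, and the source may have more. Where it says the series, first, only, none or still open, it means among the compounds named here.

Compound 1 `FC(F)(F)c1ccc(COc2ccccc2Nc2ncnc3cc4c(cc23)OCCOCCOCCO4)cc1` and compound 2 `FC(F)(F)c1ccc(COc2ccc(Nc3ncnc4cc5c(cc34)OCCOCCOCCOCCO5)cc2)cc1` share a diaryl amine built on a quinazoline-type scaffold fused to a polyether ring, but the difference between their two cores is not broken down here. In a functional assay on HepG2 cells (Homo sapiens) for antiproliferative activity, read by MTT assay, with a stated time of 72 h (on this read-out higher numbers stand for weaker inhibition and lower numbers for stronger inhibition), compound 2 gives 3340 nM. For compound 1 this assay returns only a limit, > 100000 nM, not a number.

Compound 3 `O=[N+]([O-])c1ccc(COc2ccc(Nc3ncnc4cc5c(cc34)OCCOCCOCCOCCO5)cc2)cc1` carries the change nitro in place of trifluoromethyl on an aromatic carbon relative to compound 2. For compound 3 this assay again yields only a limit, > 100000 nM. The step of an at least 29-fold higher number from compound 2 to compound 3 (1.47 log units; beyond the scatter) is therefore measured only as a lower bound, resting on (the limit of > 100000 nM in this assay, at which 2 of the 3 values shown sit), the boundary at which two of the three values sit.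

Compound 4 `O=[N+]([O-])c1ccc(COc2ccccc2Nc2ncnc3cc4c(cc23)OCCOCCOCCO4)cc1` has not yet been measured. It stands to compound 1 as compound 3 stands to compound 2: the change nitro in place of trifluoromethyl on an aromatic carbon is the same change made in the same place, on the same kind of aromatic carbon, para to a large group. Since compound 1 already sits at the limit of this assay, the expected step that the limit leaves unreadable from compound 1 to compound 4 cannot be resolved as a number, and the precedent of compound 2 to compound 3 points away from any gain. He therefore expects compound 4 to give an estimated 200000 nM in this assay, most likely reported again only as a limit.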

Compound 4, half-maximal inhibitory concentration: 60800 nM
For compound 4 the middle estimate is 3.3-fold (0.52 log units) above the measured one; measured number outside the range, below it.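

On the core of compound 1, the nitro in place of trifluoromethyl change gives an at least 1.6-fold lower number from compound 1 to compound 4 (0.21 log units; that floor lies within the scatter) in this assay, so the gain is not established as larger than the usual scatter, yet the large rise in number seen on the core of compound 2 does not recur here. The same change therefore does not carry over unaltered from one core to the other in this series, and the two steps differ clearly: the same change on two cores in this assay, an at least 29-fold higher number (1.47 log units; beyond the scatter) from compound 2 to compound 3 and an at least 1.6-fold lower number (0.21 log units; that floor lies within the scatter) from compound 1 to compound 4, at least 49-fold (1.69 log units) apart, beyond the scatter of two such steps. This does not show how large either step truly is, nor which feature of the two cores goes with the different outcomes, and both steps are bounds rather than measured sizes, each resting on a limit of the assay: the limit of > 100000 nM in this assay, at which 2 of the 4 values shown sit.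

Left open is how a nitrile, an amine, a carboxylic acid or a longer chain in the same place on the aromatic ring would read on each of the two cores. Also open, as far as these compounds go, is which part of the difference between the two cores goes with the split between the two steps, and whether the same split would appear for any change other than this one.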